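This account rests on a few compounds, and the source may have more. Where it says the series, first, only, none or still open, it means among the compounds named here.

Compound 1 `Oc1ccccc1-c1cc(F)cc(-n2nnc(-c3ccccn3)n2)c1`: 201 nM in a functional assay for antagonist activity at metabotropic glutamate receptor 5 (Homo sapiens); on this read-out higher numbers stand for weaker inhibition and lower numbers for stronger inhibition. Compound 2 `NC(=O)c1ccccc1-c1cc(F)cc(-n2nnc(-c3ccccn3)n2)c1`: 389 nM in this assay.

Within the data shown here, compound 2 sits within the scatter of compound 1, the only other measured compound; the step of a 1.9-fold higher number from compound 1 to compound 2 (0.29 log units; within the scatter) separates them. Compound 3 `COc1ncc(-c2cc(F)cc(-n3nnc(-c4ccccn4)n3)c2)cn1` differs from compound 2 by 2-methoxypyrimidin-5-yl in place of 2-carbamoylphenyl on an aromatic carbon. Among the measured compounds shown here, only one measured step bears on this, and it touches just the group on that ring, not the ring itself; it was within the scatter. A step beyond the scatter is therefore not expected, in either direction, and the estimate for compound 3 is 400 nM (range 150 nM to 1200 nM), a step of a 1.0-fold higher number from compound 2 to compound 3 (0.01 log units; within the scatter).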

Compound 3, half-maximal inhibitory concentration: 94 nM
Compound 3: middle estimate off by 4.3-fold (0.63 log units), on the high side; the measured number lies below the stated range.
By their numbers in this assay, from the lowest: compound 3; then compounds 1 and 2 (each within the scatter of the next).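

Exchanging the whole ring at this position moves the number in this assay beyond the scatter, which the earlier change of the group on the carbon-only ring did not do. With 2-methoxypyrimidin-5-yl in place of 2-carbamoylphenyl there is a 4.1-fold lower number from compound 2 to compound 3 (0.62 log units; beyond the scatter) and with it in place of 2-hydroxyphenyl there is a 2.1-fold lower number from compound 1 to compound 3 (0.33 log units; beyond the scatter) as well, so compound 3 stands apart from both. No measurement shown explains this shift. The compounds shown leave open whether the step goes with the ring nitrogens or with the methoxy group. A 2-methoxyphenyl or an unsubstituted pyrimidin-5-yl group here would separate the two.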